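A Halogen Swap on the Phenoxy Arm

The source may hold more compounds than are shown below. What is called first, only, known or untested is meant among the compounds shown, and "the series" means these compounds.

Compound 1 `Cc1nn(C)c(Oc2ccc(F)cc2)c1/C=N\CCCCCOc1cc2oc(=O)cc(C)c2cc1Cl` gives in a functional assay on U-87MG ATCC cells for antiproliferative activity against U-87 MG (Homo sapiens), read by MTT assay, with a stated time of 72 h (a lower number here means a stronger inhibitor, a higher number a weaker inhibitor), only a limit, > 25000 nM, not a number.
Compound 2 `Cc1nn(C)c(Oc2ccccc2F)c1/C=N\CCCCCCOc1cc2oc(=O)cc(C)c2cc1Cl` gives in this assay the limit > 25000 nM.
Compound 3 `Cc1nn(C)c(Oc2cccc(F)c2)c1/C=N\CCCCCCOc1cc2oc(=O)cc(C)c2cc1Cl` gives in this assay the limit > 25000 nM.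

Compound 3 therefore stands where all measured members of this small series stand: at the upper limit of this assay, with no real number behind it. This is summed up by the limit of > 25000 nM in this assay, at which 3 of the 3 values shown sit. Among the compounds with values here, the one single-point step that the data allow, a step that the two limits leave unreadable from compound 2 to compound 3, has a size that cannot be read, since both ends of it are limits.

Compound 4 `Cc1nn(C)c(Oc2ccc(I)cc2)c1/C=N\CCCCCCOc1cc2oc(=O)cc(C)c2cc1Cl` differs from compound 3 by 4-iodophenyl in place of 3-fluorophenyl on an oxygen on an aromatic ring. Within the data shown here, no measured step touches an iodine on this ring, so the only guide is that every change tried so far on the phenoxy group has left the result at the limit. Compound 4 is therefore expected to give 30000 nM, in a range from 8000 nM to 100000 nM. The step that the limit leaves unreadable from compound 3 to compound 4 is expected to be none beyond the scatter, and most likely compound 4 will again be reported only as a limit.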

Compound 4, half-maximal inhibitory concentration: 16800 nM
Compound 4: middle estimate off by 1.8-fold (0.25 log units), on the high side; measured number inside the range.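

Within the data shown here, compound 4 gives the first real number in this assay, so the 4-iodophenyl group on this oxygen brings the result within the range that the assay can read. As far as these compounds go, the change from the 3-fluorophenyl group reads as an at least 1.4-fold lower number from compound 3 to compound 4 (0.17 log units; that floor lies within the scatter), and the change from the 2-fluorophenyl group reads as an at least 1.4-fold lower number from compound 2 to compound 4 (0.17 log units; that floor lies within the scatter); both are only floors, since the starting value in each is a limit, so the true size of either step stays unknown. Compound 1, compound 2 and compound 3 remain at a limit, not a number: the limit of > 25000 nM in this assay, at which 3 of the 4 values shown sit.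

Both the halogen and its place on the ring change in these steps, so the compounds shown cannot tell the two changes apart. From the compounds shown here alone, how a bromine or a methoxy group in place of the iodine would read remains open.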